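Benzyloxy in place of methoxy on the aryl ring

A few compounds are considered here, and "the series" means these few. Any claim that something is new, unique, unknown or untested is made for them only; others in the source may bear on it.

Measured so far:
compound 1 `COC(=O)C1=C(C)NC(=O)NC1c1ccc(OC)cc1` — 59200 nM
compound 2 `COC(=O)C1=C(C)NC(=O)NC1c1ccc(OC)c(OC)c1` — "not active" (no number reported)

In an assay for inhibition of beta-glucuronidase (Bos taurus), read by spectrophotometry, with a stated time of 30 min (a higher number here means a weaker inhibitor, a lower number a stronger inhibitor), compound 1 gives 59200 nM, a weak result. In this assay compound 2 is reported as "not active" (no number reported) with no number attached, so compound 2 stands without a single value here, and only the fact that compound 1 has a number and compound 2 has none can be read from the two.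

Compound 3 `COC(=O)C1=C(C)NC(=O)NC1c1ccc(OC)c(OCc2ccccc2)c1` is not yet measured. It differs from compound 2 by phenyl in place of hydrogen on a saturated chain carbon bound to an oxygen on an aromatic ring. For the measured compounds named here, no measured pair shows this change, so the size of the step in this assay cannot be taken from the data. Given that compound 2 returned no number, any step from compound 2 to compound 3 is expected to be small or to stay beyond the scatter only if the added group restores measurable inhibition; no direction can be stated firmly. Compound 3 is estimated at 120000 nM in this assay, with a range from 30000 nM to 500000 nM, and a substantial chance that only a limit is reported.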

Compound 3, half-maximal inhibitory concentration: "not active" (no number reported)
The entry for compound 3 holds no number; no gap can be computed for the estimate.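

In this assay, for the compounds shown here, compound 2 and compound 3 both stand without a number, so no step from methoxy to benzyloxy can be read. No supporting data bear on this result. The compounds shown leave open whether benzyloxy in place of methoxy changes inhibition at all.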